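The compounds below may be only part of what the source reports. "The series", "measured", "known", "first", "only" and "open" are said of these compounds alone.

Measured so far in a physicochemical assay for lipophilicity, read by HPLC, measured as octanol-water partition; a lower number here means a more polar compound, a higher number a more lipophilic compound:
- compound 1 `Cc1nc(O)c2c[nH]nc2n1`: -0.05
- compound 2 `CCCc1nc(O)c2c[nH]nc2n1`: 1.14
- compound 3 `CC(=O)n1ncc2c(=O)[nH]cnc21`: 0.4

For the measured compounds named here, of these three numbers, the one for compound 3, 0.4, is the second highest, and its gaps to compound 1 and to compound 2 both lie beyond the scatter of repeated measurements.

The next compound, compound 4 `CCCC(=O)n1ncc2c(=O)[nH]cnc21`, has not yet been measured. It differs from compound 3 in one place: ethyl in place of hydrogen on a saturated chain carbon bound to a carbonyl carbon. Put another way, acetyl becomes propylcarbonyl.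

Going by the values given here, only one measured step bears on this change. It is the same exchange of hydrogen for ethyl, but on a saturated chain carbon bound to an aromatic carbon, and it gave a number 1.19 log units higher from compound 1 to compound 2 (beyond the scatter). A single step from a different place is a thin guide, so its size can be carried over only loosely, and the range has to stay wide. In this assay the expected change is a number 1.10 log units higher from compound 3 to compound 4 (beyond the scatter), a large upward step beyond the scatter. Compound 4 is expected at about 1.5, with an estimated range from 1 to 2.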

Compound 4, partition coefficient: 1.99
The estimate for compound 4 lay 0.49 log units below the measured number, and the stated range covers the measured number.
By their numbers in this assay, from the lowest: compound 1; then compound 3; then compound 2; then compound 4.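

In this assay, ethyl in place of hydrogen on a saturated chain carbon bound to a carbonyl carbon gives a number 1.59 log units higher from compound 3 to compound 4 (beyond the scatter), so the exchange now has a large measured effect at this place as well as on a chain carbon bound to an aromatic carbon. The earlier exchange gave a number 1.19 log units higher from compound 1 to compound 2 (beyond the scatter), and with two pairs on record, both steps point upward and neither pair goes against that direction, although two pairs are still a small basis for any rule. No measurement shown here explains why the number moves so far at this position.

The compounds shown leave open whether the rise in this assay continues with a longer chain, such as butyl in place of the propyl end of the propylcarbonyl group, or whether it levels off. They also leave open what a chain ending in an amine or a carboxylic acid would do at this position, since every change seen so far adds only ethyl to a saturated chain carbon.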